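The compounds below may be only part of what the source reports. "The series", "measured", "known", "first", "only" and "open" are said of these compounds alone.

Values measured so far in a functional assay on HeLa cells (Homo sapiens) for inhibition, read by MTT assay, with a stated time of 48 h; a lower number here means a stronger inhibitor, a higher number a weaker inhibitor

- compound 1 `Oc1cccc(C(c2c[nH]c3ccc(Br)cc23)c2c[nH]c3ccc(Br)cc23)c1` gives 3900 nM
- compound 2 `COc1ccc(C(c2c[nH]c3ccc(Br)cc23)c2c[nH]c3ccc(Br)cc23)c(OC)c1` gives 63200 nM
- compound 3 `CN(C)c1ccc(C(c2c[nH]c3ccc(Br)cc23)c2c[nH]c3ccc(Br)cc23)cc1` gives 12800 nM

Compound 1 is the strongest inhibitor of the three, and compound 3 comes nearest to it. Compound 4 `Brc1ccc2[nH]cc(C(c3c[nH]c4ccc(Br)cc34)C3CCCCC3)c2c1` is still unmeasured. Its difference from compound 1 is cyclohexyl in place of 3-hydroxyphenyl on a saturated chain carbon bound to two aromatic carbons with cyclohexyl in place of 3-hydroxyphenyl on a saturated chain carbon bound to two aromatic carbons. Two measured steps also replace the 3-hydroxyphenyl there. One is a 3.3-fold higher number from compound 1 to compound 3 (0.52 log units; beyond the scatter) and the other is a 16-fold higher number from compound 1 to compound 2 (1.21 log units; beyond the scatter) in the same direction. Neither brings in a non-aromatic ring, so they guide only loosely. A rise of modest size is therefore expected in this assay here. The estimated change is a 3.8-fold higher number from compound 1 to compound 4 (0.59 log units; beyond the scatter) as a middle guess. For compound 4 the expected value is 15000 nM with an estimated range from 5000 nM to 50000 nM once measured.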

Compound 4, half-maximal inhibitory concentration: 3200 nM
The estimate for compound 4 lay 4.7-fold (0.67 log units) above the measured number, outside the stated range (below it).
By their numbers in this assay, from the lowest: compounds 4 and 1 (each within the scatter of the next); then compound 3; then compound 2.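

In this assay, this position does not need an aromatic ring or a hydrogen-bond donor: swapping 3-hydroxyphenyl for cyclohexyl gives a 1.2-fold lower number from compound 1 to compound 4 (0.09 log units; within the scatter). Cyclohexyl also outperforms the other two aromatic groups, with a 4.0-fold lower number from compound 3 to compound 4 (0.60 log units; beyond the scatter) and a 20-fold lower number from compound 2 to compound 4 (1.30 log units; beyond the scatter), so these aromatic groups offer no advantage over a plain saturated ring. Nothing measured here accounts for these differences. Still open, as far as these compounds go, is whether cyclopentyl, a straight butyl chain, or a cyclohexyl ring carrying a hydroxyl or an amine would keep this level of inhibition.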